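The source may report more compounds than this note shows. Statements on the series, on what has been measured and on what is new or still open speak of the compounds shown alone.

Measured compounds in an assay on HEK293 cells for antagonist activity at Toll-like receptor 9 (Homo sapiens), read by spectrophotometry; on this read-out higher numbers stand for weaker inhibition and lower numbers for stronger inhibition:
Compound 1, `CCN1CCN(CCCn2cnc3c(N4CCN(C(=O)C5CCCC5)CC4)nc(NCc4ccc(OC)cc4)nc32)CC1`: compound 1 reaches only > 30000 nM, which is a limit of the assay and not a number.
Compound 2, `Fc1ccc(CNc2nc(N3CCN(C4CCCC4)CC3)c3ncn(CCCN4CCCC4)c3n2)cc1`: compound 2 gives 100 nM.
Compound 3, `CCN1CCN(CCCn2cnc3c(N4CCN(CC)CC4)nc(N4CCCC4)nc32)CC1`: compound 3 gives 500 nM.

Of the two numbers, compound 3 stands highest; compound 2 gives the lower number, and the gap lies beyond the scatter. Compound 2 differs from compound 3 in more than one place, so its lower number cannot be tied to a single change. For compound 1 only the limit of > 30000 nM in this assay, at which 1 of the 3 values shown sits, is recorded.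

Compound 4, `CCN1CCN(CCCn2cnc3c(N4CCN(CC)CC4)nc(NCc4ccc(OC)cc4)nc32)CC1`, differs from compound 3 in one place: (4-methoxybenzyl)amino in place of pyrrolidin-1-yl on an aromatic carbon. No step between measured compounds describes this change on its own, so the expectation rests on the spread of the shown values. A modest step downward in this assay is expected, of about a 2.5-fold lower number from compound 3 to compound 4 (0.40 log units; beyond the scatter), a size close to the edge of the scatter, since compound 2 with 100 nM shows that an amino-linked benzyl group at this position of the shared core is compatible with a lower number than compound 3. Compound 4 is therefore estimated at 200 nM, expected to fall within 60 nM to 700 nM.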

Compound 4, half-maximal inhibitory concentration: 200 nM
Beside the measured number, compound 4's estimate shows no gap at the digits printed; measured number inside the range.
By their numbers in this assay, from the lowest: compounds 2 and 4 (each within the scatter of the next); then compound 3. At a limit, above all of these: compound 1.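

In this assay, among the compounds shown here, a 2.5-fold lower number from compound 3 to compound 4 (0.40 log units; beyond the scatter) with (4-methoxybenzyl)amino in place of pyrrolidin-1-yl on the aromatic carbon between two ring nitrogen atoms, giving the first single-place reading at this position, a modest one, and favouring the larger amino-linked benzyl group over the ring amine. On the amine nitrogen in a ring, ethyl in place of cyclopentylcarbonyl gives an at least 150-fold lower number from compound 1 to compound 4 (2.17 log units; beyond the scatter), a large step that marks this second site as far more sensitive in this series than the position between the ring nitrogens. The value of compound 1 is a limit of the assay and not a number, so this step gives only a minimum size: the limit of > 30000 nM in this assay, at which 1 of the 4 values shown sits.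

The change at the aromatic carbon brings in both an amine hydrogen and a benzene ring, and the compounds shown do not separate the two; a plain amino group or an N-methyl-N-benzylamino group at this position would bear on that. As far as these compounds go, on the ring nitrogen, it stays open whether the loss goes with the carbonyl or with the cyclopentyl ring, which an acetyl group or a cyclopentyl group on the same core would help to settle.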